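Hydroxy in Place of Methyl: Expecting the Efficacy Step

The source may report more compounds than this note shows. Statements on the series, on what has been measured and on what is new or still open speak of the compounds shown alone.

Compound 1 `O=C(O)Cc1sc(C(c2ccc(F)cc2)c2ccc(F)cc2)nc1-c1ccncc1` and compound 2 `Cc1cc(-c2nc(C(c3ccc(F)cc3)c3ccc(F)cc3)sc2CC(=O)O)ccn1` share one core and differ only by a methyl in place of hydrogen on an aromatic carbon. In an in vitro functional assay on HEK285-7 cells for antagonist activity at prostaglandin D2 receptor 2 (Homo sapiens), read by BRET and beta-arrestin recruitment (on this read-out lower numbers stand for smaller maximal responses and higher numbers for larger maximal responses), compound 1 reaches 80%, and compound 2 reaches 80%; the step of no change at the digits printed from compound 1 to compound 2 (within the scatter) shows no movement. For the measured compounds named here, compound 2 thus stands level with compound 1, the only other compound measured so far.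

Compound 3 `O=C(O)Cc1sc(C(c2ccc(F)cc2)c2ccc(F)cc2)nc1-c1ccnc(O)c1` has not yet been measured. Its change from compound 2 is hydroxy in place of methyl on an aromatic carbon. Going by the values given here, the single measured step, no change at the digits printed from compound 1 to compound 2 (within the scatter), was flat, and no measured pair shows what a hydroxy group does on this core, so the expectation rests on that flat step alone, with added uncertainty for a group that has not been tried. A step of about a number 4 percentage points lower from compound 2 to compound 3 (within the scatter) is expected in this assay, that is, nothing clearly beyond the usual scatter. Compound 3 is accordingly estimated to reach 76%, with a likely range from 55% to 95%.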

Compound 3, largest response reached (reported as efficacy), in percent of the reference or control that the assay uses: 60%
The estimate for compound 3 lay 16 percentage points above the measured number; the measured number falls inside the stated range.
By their numbers in this assay, from the lowest: compound 3; then compounds 1 and 2 (each within the scatter of the next).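

In this assay the swap to hydroxy on this aromatic carbon, next to the ring nitrogen, gives a number 20 percentage points lower from compound 2 to compound 3 (beyond the scatter) when it replaces methyl and a number 20 percentage points lower from compound 1 to compound 3 (beyond the scatter) when it replaces hydrogen. The earlier pair could suggest that this position tolerates any change, since methyl in place of hydrogen gave no change at the digits printed from compound 1 to compound 2 (within the scatter) and left those two compounds level. Compound 3 shows instead that the maximal response does depend on what sits here, with 2-hydroxypyridin-4-yl standing apart from 2-methylpyridin-4-yl and from the unsubstituted ring of compound 1. No measurement at hand explains why the hydroxy group has this effect, so the step can only be recorded, not accounted for.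

The three compounds cover only hydrogen, methyl and hydroxy at this one position, so they leave open whether the lower response belongs to hydroxy alone or would also appear with a methoxy group, an amine or a fluorine atom. They also leave open whether the same swap would give a similar step elsewhere on the ring or on a core with a different chain in place of the acetic acid side chain.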